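Nitro Added to a Trifluoromethylsulfonamide Anilide: Cytotoxicity Expected

The compounds below may be only part of what the source reports. "The series", "measured", "known", "first", "only" and "open" are said of these compounds alone.

Measured compounds:
Compound 1, `COc1cc(NC(=O)c2ccc(Cl)c([N+](=O)[O-])c2)ccc1NS(C)(=O)=O`, gives 164000 nM in an ADME assay on HEK293 cells (Homo sapiens) for cytotoxicity, read by MTT assay, with a stated time of 48 h; a higher number here means a weaker inhibitor, a lower number a stronger inhibitor.
Compound 2, `COc1cc(NC(=O)c2ccc(Cl)cc2)ccc1NS(=O)(=O)C(F)(F)F`, gives > 250000 nM in this assay.

Compound 2 sits at the limit of this assay; its result is a limit, not a number. That limit is described as the limit of > 250000 nM in this assay, at which 1 of the 2 values shown sits. For the measured compounds named here, compound 1 carries a nitro group and a methylsulfonamide and gives a plain number in this assay, while compound 2 lacks the nitro group and carries a trifluoromethylsulfonamide; no step between them is defined, as they differ in two places, so only the two values themselves can be compared.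

Compound 3, `COc1cc(NC(=O)c2ccc(Cl)c([N+](=O)[O-])c2)ccc1NS(=O)(=O)C(F)(F)F`, has not yet been measured in this assay. It differs from compound 2 by nitro in place of hydrogen on an aromatic carbon. Since compound 2 gives only a limit, no size of this step can be read from a measured pair. The nitro-bearing compound 1 gives 164000 nM, which suggests the step of an at least 1.2-fold lower number from compound 2 to compound 3 (0.09 log units; that floor lies within the scatter) is expected to be small or within the scatter. For compound 3 an estimated value of 200000 nM is expected, within a range from 80000 nM to 400000 nM.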

Compound 3, half-maximal inhibitory concentration: > 250000 nM
Compound 3 ended at the assay's limit; the forecaster's own chance of this, stated with the estimate: 45%; middle value at least 1.2-fold (0.09 log units) from the limit.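

For the compounds shown here, with compound 3, the nitro group ortho to a chloro group and the trifluoromethylsulfonamide stand together for the first time, and in this assay compound 3 gives > 250000 nM, which is a limit and not a number. Adding nitro in place of hydrogen on this aromatic carbon did not bring the result off the limit, but the size of that step cannot be read because compound 2 and compound 3 both end at a limit: the limit of > 250000 nM in this assay, at which 2 of the 3 values shown sit. Compound 1 and compound 3 now form a pair that differs in one place, trifluoromethyl in place of methyl on a sulfonyl sulfur, and this change gives an at least 1.5-fold higher number from compound 1 to compound 3 (0.18 log units; that floor lies within the scatter), so only a floor is known and that floor does not clear the scatter.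

The compounds shown leave open how far past the limit compound 2 and compound 3 lie, and whether nitro in place of hydrogen changes the read-out at all when the sulfonamide carries trifluoromethyl. They also leave open whether an amine or a carboxylic acid at this position would give a plain number in this assay.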